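This account rests on a few compounds, and the source may have more. Where it says the series, first, only, none or still open, it means among the compounds named here.

Measured in a functional assay on HepG2 cells (Homo sapiens) for antiproliferative activity, read by MTT assay, with a stated time of 24 h (on this read-out lower numbers stand for stronger inhibition and higher numbers for weaker inhibition), so far:
compound 1 (`Cc1ccc(-c2nn(-c3ccccc3)cc2-c2nc3ccccc3n2S(=O)(=O)c2cc(C)ccc2C)cc1`) gives 460 nM
compound 2 (`Cc1ccc(-c2nn(-c3ccccc3)cc2-c2nc3ccccc3n2S(=O)(=O)c2ccc(F)cc2)cc1`) gives 5060 nM

Compound 2 has the higher of the two numbers, and so the weaker inhibition. Compound 3 (`Cc1ccc(-c2nn(-c3ccccc3)cc2-c2nc3ccccc3n2S(=O)(=O)c2ccc(Cl)cc2)cc1`) is still to be measured. It differs from compound 2 in one substituent (chloro in place of fluoro on an aromatic carbon) with chloro in place of fluoro on an aromatic carbon, para to a large group.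

Going by the values given here, only one measured step bears on this change, and it concerns the same group on the sulfonyl sulfur. The step is an 11-fold higher number from compound 1 to compound 2 (1.04 log units; beyond the scatter) and is large, beyond the scatter. Among the compounds with values here, that step exchanged the whole substituent, whereas here only the halogen changes, and no pair differing in the halogen alone has been measured. A step of that size is therefore not expected. A small step is expected instead, probably within the scatter, with a slight lean towards a lower number. The estimate means a 1.4-fold lower number from compound 2 to compound 3 (0.16 log units; within the scatter) as the expected change. For compound 3 the estimated value in this assay is 3500 nM with an expected range from 1200 nM to 9000 nM on repeated measurement.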

Compound 3, half-maximal inhibitory concentration: 5520 nM
Compound 3: middle estimate off by 1.6-fold (0.20 log units), on the low side; the range from low to high includes it.
By their numbers in this assay, from the lowest: compound 1; then compounds 2 and 3 (each within the scatter of the next).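

In this assay, chloro in place of fluoro gives a 1.1-fold higher number from compound 2 to compound 3 (0.04 log units; within the scatter), so on this aromatic carbon, para to a large group, the two halogens cannot be told apart. Replacing 2,5-dimethylphenyl on the sulfonyl sulfur with 4-chlorophenyl gives a 12-fold higher number from compound 1 to compound 3 (1.08 log units; beyond the scatter), a large step like an 11-fold higher number from compound 1 to compound 2 (1.04 log units; beyond the scatter), so the gap from compound 1 is not specific to the 4-fluorophenyl group and appears with both halogen-bearing rings shown. No measurement available here offers an explanation for these results.

The compounds shown leave open whether the lower number of compound 1 in this assay depends on both methyl groups, on one of them, or on their placement, as 2,5-dimethylphenyl is compared only with rings carrying a single halogen. Also open, going by these compounds, is how an unsubstituted phenyl, or a single methyl, methoxy or amino group in place of the halogen, would read in this assay.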